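The source may hold more compounds than are shown below. What is called first, only, known or untested is meant among the compounds shown, and "the series" means these compounds.

Working notes on the series, values in a functional assay on A549 cells (Homo sapiens) for antiproliferative activity, read by MTT assay, with a stated time of 48 h; a higher number here means a weaker inhibitor, a lower number a stronger inhibitor:

- compound 1 `Oc1ccc2cc1Oc1ccc(cc1)CCc1ccc(CN3CCCC3)c(O)c1-c1ccc(cc1O)CC2`: 2260 nM
- compound 2 `COc1ccc(N2CCN(Cc3ccc4c(c3O)-c3ccc(cc3O)CCc3ccc(O)c(c3)Oc3ccc(cc3)CC4)CC2)cc1`: > 20000 nM
- compound 3 `CN1CCN(Cc2ccc3c(c2O)-c2ccc(cc2O)CCc2ccc(O)c(c2)Oc2ccc(cc2)CC3)CC1`: 5590 nM
- compound 4 `CCCCN(CCCC)Cc1ccc2c(c1O)-c1ccc(cc1O)CCc1ccc(O)c(c1)Oc1ccc(cc1)CC2`: not yet measured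

The entry for compound 2 is a limit of the assay and not a number. Compound 1, at 2260 nM, holds the lowest of the two numeric values, and compound 3 is its nearest neighbour, with a 2.5-fold higher number from compound 1 to compound 3 (0.39 log units; beyond the scatter).

The step to compound 4 is dibutylamino in place of pyrrolidin-1-yl on a saturated chain carbon bound to an aromatic carbon. For the measured compounds named here, no measured step carries dibutylamino, so the nearest guide is another amine exchange at the same place, a 2.5-fold higher number from compound 1 to compound 3 (0.39 log units; beyond the scatter). A second amine comparison, an at least 3.5-fold lower number from compound 2 to compound 3 (0.55 log units; beyond the scatter), shows that the substituent on an amine nitrogen in a ring can also move the number. Among the three measured compounds, the pyrrolidin-1-yl compound gives the lowest number, and no compound goes against this. A modest rise in this assay is therefore expected, meaning a weaker inhibitor.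

The estimated change is a 2.2-fold higher number from compound 1 to compound 4 (0.34 log units; beyond the scatter). Compound 4 is expected at 5000 nM, with an estimated range of 1800 nM to 16000 nM.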

Compound 4, half-maximal inhibitory concentration: > 20000 nM
Compound 4 ended at the assay's limit; the forecaster's own chance of this, stated with the estimate: 10%; at least 4.0-fold (0.60 log units) between middle value and limit.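

In this assay the entry for compound 4, > 20000 nM, is a limit of the assay and not a number. On a saturated chain carbon bound to an aromatic carbon, dibutylamino, which has no ring, gives an at least 8.8-fold higher number from compound 1 to compound 4 (0.94 log units; beyond the scatter) and also an at least 3.5-fold higher number from compound 3 to compound 4 (0.55 log units; beyond the scatter), so the amine at this place can move the number further than the exchange between the two ring amines showed. The true size of both steps remains unresolved, as they rest on the limit of the assay: the limit of > 20000 nM in this assay, at which 2 of the 4 values shown sit.

The compounds shown leave open whether the number follows the length of the chains on the amine or the presence of a ring. Dimethylamino, with shorter chains, and piperidin-1-yl, a further ring amine, would bear on this question.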